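The source may hold more compounds than are shown below. What is called first, only, known or untested is meant among the compounds shown, and "the series" means these compounds.

Working notes on the series, read in a functional assay on RAW264.7 cells (Mus musculus) for inhibition, read by fluorescence, with stated times of 1 h, 24 h and 30 min; on this read-out higher numbers stand for weaker inhibition and lower numbers for stronger inhibition.

- Compound 1 `O=C(/C=C/c1ccc(F)cc1)c1ccc(O)cc1`: > 10000 nM, a limit.
- Compound 2 `O=C(/C=C/c1ccc(C(F)(F)F)cc1)c1ccc(O)cc1`: > 10000 nM, a limit.
- Compound 3 `O=C(/C=C/c1ccc(OC(F)(F)F)cc1)c1cccc(O)c1`: > 10000 nM, a limit.

Compound 3 gives no number, and neither does any other measured compound. The position of the series in this assay is the limit of > 10000 nM in this assay, at which 3 of the 3 values shown sit.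

The next compound is compound 4 `O=C(/C=C/c1ccc(OC(F)(F)F)cc1)c1ccc(O)cc1`. The change is 4-hydroxyphenyl in place of 3-hydroxyphenyl on a carbonyl carbon.

Among the measured compounds shown here, the only measured step is a step that the two limits leave unreadable from compound 1 to compound 2. It concerns trifluoromethyl in place of fluoro on an aromatic carbon, not the change at hand, and it gives no size to carry over. For the measured compounds named here, no measured step covers the exchange of 3-hydroxyphenyl for 4-hydroxyphenyl.

Some indirect guidance comes from the two compounds that already carry 4-hydroxyphenyl. Compound 1 has this group and stands at > 10000 nM, a limit. Compound 2 also has it and stands at > 10000 nM, again a limit.

On this basis, no step beyond the scatter is expected in either direction, and compound 4 will most likely report a limit too. The expected change is a step that the limit leaves unreadable from compound 3 to compound 4. For compound 4 the estimated value is 12000 nM, with an expected range from 4000 nM to 30000 nM.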

Compound 4, half-maximal inhibitory concentration: > 10000 nM
Compound 4 ended at the assay's limit; the forecaster's own chance of this, stated with the estimate: 70%; the middle value lies beyond the limit too.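

Compound 4 gives > 10000 nM, a limit. The steps to compound 4 from compound 1, compound 2 and compound 3 cannot be read; both ends of each are limits. The compounds shown leave open whether any of these compounds has a measurable half-maximal inhibitory concentration in this assay, and how 4-hydroxyphenyl compares with 3-hydroxyphenyl there.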